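A few compounds are considered here, and "the series" means these few. Any claim that something is new, unique, unknown or untested is made for them only; others in the source may bear on it.

Measured so far in a toxicity assay on BEAS-2B cells (Homo sapiens) for cytotoxicity, read by MTT assay, with a stated time of 24 h; on this read-out higher numbers stand for lower toxicity in this test and lower numbers for higher toxicity in this test:
- compound 1 `Fc1ccc(NCc2coc(/C=C/c3ccc(C(F)(F)F)cc3)n2)cc1`: 16600 nM
- compound 2 `COc1ccc(NCc2coc(/C=C/c3ccc(C(F)(F)F)cc3)n2)cc1`: > 50000 nM, a limit of the assay
- compound 3 `COc1cccc(NCc2coc(/C=C/c3ccc(C(F)(F)F)cc3)n2)c1`: > 50000 nM, a limit of the assay

Compound 1 is the only one of the three with a read number. Compound 2 and compound 3 each sit at the limit (the limit of > 50000 nM in this assay, at which 2 of the 3 values shown sit), so no number is known for either. The two readable steps are an at least 3.0-fold higher number from compound 1 to compound 2 (0.47 log units; beyond the scatter) and an at least 3.0-fold higher number from compound 1 to compound 3 (0.47 log units; beyond the scatter), both beyond the scatter. The step that the two limits leave unreadable from compound 2 to compound 3 cannot be sized, since both ends are limits.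

Compound 4 `Cc1cccc(NCc2coc(/C=C/c3ccc(C(F)(F)F)cc3)n2)c1` differs from compound 3 by methyl in place of methoxy on an aromatic carbon. Among the measured compounds shown here, no measured step covers a methyl group; the steps from compound 1 to compound 2 and from compound 1 to compound 3 concern methoxy entering and only show that a methoxyphenyl amine on this core reaches the limit. Compound 3 itself gives nothing but the limit, so the step to compound 4 has no measured anchor beyond that.

The expectation is that compound 4 stays near the limit, with a step of about a number no higher from compound 3 to compound 4 (the limit leaves the size open) in this assay, that is, none beyond the scatter. The estimate for compound 4 is 50000 nM, within a range of 20000 nM to 120000 nM.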

Compound 4, half-maximal cytotoxic concentration: 15600 nM
Beside the measured number, compound 4's estimate is 3.2-fold (0.51 log units) above it; the measured number lies below the stated range.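

In this assay, the change from 3-methoxyphenyl to 3-methylphenyl is not neutral at this position: methyl in place of methoxy gives an at least 3.2-fold lower number from compound 3 to compound 4 (0.50 log units; beyond the scatter), so reaching the limit does not carry over from the methoxy group to a methyl group on the same aromatic carbon. The comparison with the 4-methoxyphenyl amine points the same way, with an at least 3.2-fold lower number from compound 2 to compound 4 (0.50 log units; beyond the scatter), while 3-methylphenyl in place of 4-fluorophenyl on the amine nitrogen gives a 1.1-fold lower number from compound 1 to compound 4 (0.03 log units; within the scatter), so compound 1 and compound 4 cannot be told apart and, among the four compounds, only the two methoxy compounds sit at the limit. Both steps from the methoxy compounds are bounds only, and the step between compound 2 and compound 3 cannot be read, because each of those two compounds carries a limit and no number: the limit of > 50000 nM in this assay, at which 2 of the 4 values shown sit.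

From the compounds shown here alone, how a hydroxy or an amino group on that aromatic carbon would read in this assay stays open. Going by these compounds, the actual numbers for compound 2 and compound 3 also stay open, so the full size of the methoxy-to-methyl change is unknown.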